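The source may hold more compounds than are shown below. What is called first, only, known or untested is meant among the compounds shown, and "the series" means these compounds.

Measured compounds:
compound 1 `COCC(C(=O)N1CCN(c2cccc(C(F)(F)F)c2)CC1)N1C(=O)CCC1=O` — 50%
compound 2 `CC(C(=O)N1CCN(c2ccccc2)CC1)N1C(=O)CCC1=O` — 0%
compound 3 `CC(C(=O)N1CCN(c2cccc(F)c2)CC1)N1C(=O)CCC1=O` — 0%

In a functional assay on the whole organism (strain Swiss) with Mus musculus as the target, in the maximal electroshock model, with a stated time of 1 h, at a dose of 100 mg/kg by the intraperitoneal route (a lower number here means a weaker effect, a higher number a stronger effect of the compound at the dose given), compound 3 gives 0%. Compound 3 stands level with compound 2 at the digits shown, and the two together are the lowest of the three numbers; the only measured step that reaches compound 3, no change at the digits printed from compound 2 to compound 3 (within the scatter), lies within the scatter. Compound 1 is the furthest from compound 3, with a value beyond the scatter above it.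

The unmeasured compound 4 `CC(C(=O)N1CCN(c2cccc(C(F)(F)F)c2)CC1)N1C(=O)CCC1=O` differs from compound 3 in one place: trifluoromethyl in place of fluoro on an aromatic carbon. Among the compounds with values here, no measured step covers this exact change. Within the data shown here, the one step that bears on the same aromatic carbon, no change at the digits printed from compound 2 to compound 3 (within the scatter), was flat. Compound 1 carries the same trifluoromethyl group on that carbon but differs from compound 4 in a second place as well. The value of compound 1, 50%, can therefore only hint that a trifluoromethyl-bearing compound can reach a clearly higher number than compound 2 or compound 3.

Weighing the flat step against the higher number of compound 1, compound 4 is expected to rise modestly, by a number 25 percentage points higher from compound 3 to compound 4 (beyond the scatter). The estimate for compound 4 is 25%, with a range from 0% to 55%.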

Compound 4, a percentage reported as activity, at one dose (the size of the read-out at that dose, not a potency): 50%
Beside the measured number, compound 4's estimate is 25 percentage points below it, and the stated range covers the measured number.
By their numbers in this assay, from the lowest: compounds 2 and 3 (each within the scatter of the next); then compounds 1 and 4 (each within the scatter of the next).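

In this assay, trifluoromethyl on this aromatic carbon gives a number 50 percentage points higher from compound 3 to compound 4 (beyond the scatter) and also a number 50 percentage points higher from compound 2 to compound 4 (beyond the scatter) in the comparison with hydrogen, while fluoro in place of hydrogen had given no change at the digits printed from compound 2 to compound 3 (within the scatter) at the same carbon, so the earlier flat step did not hold for every group placed there. The methoxy on the saturated chain carbon of compound 1 now has a direct comparison, with hydrogen in its place giving no change at the digits printed from compound 1 to compound 4 (within the scatter) in this series, which means that the number of compound 1 can be matched without that methoxy when trifluoromethyl is on the aromatic carbon. Nothing available explains why trifluoromethyl and fluoro part ways at this carbon.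

As far as these compounds go, whether a chloro, a nitrile or a methoxy group on the same aromatic carbon would follow fluoro or trifluoromethyl remains open. So does whether an amine or a longer chain on the saturated chain carbon would leave the number where it stands, and how any of these compounds would compare at other doses.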